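Substituent on the ring nitrogen of compound 2

The source may hold more compounds than are shown below. What is called first, only, known or untested is meant among the compounds shown, and "the series" means these compounds.

Compound 2 `COc1ccc(-c2nc3cc(/C=C4\SC(=O)NC4=O)ccc3[nH]2)cc1OC` gives 2430 nM in a functional assay on HT-1080 cells (Homo sapiens) for inhibition, read by MTT assay, with a stated time of 48 h (a lower number here means a stronger inhibitor, a higher number a weaker inhibitor), the lowest of the three numbers shown, yet within the scatter of compound 1 `COc1cc(-c2nc3cc(/C=C4\SC(=O)NC4=O)ccc3[nH]2)cc(OC)c1OC` at 3120 nM and of compound 3 `COc1cc(-c2nc3cc(/C=C4\SC(=O)NC4=O)ccc3[nH]2)ccc1OCC(C)C` at 4450 nM. The two measured steps, a 1.3-fold lower number from compound 1 to compound 2 (0.11 log units; within the scatter) and a 1.8-fold higher number from compound 2 to compound 3 (0.26 log units; within the scatter), both sit on the aryl side of the shared core and both stay within the scatter. Compound 4 `COc1ccc(-c2nc3cc(/C=C4\SC(=O)N(CC(=O)N5CCOCC5)C4=O)ccc3[nH]2)cc1OC` differs from compound 2 by ((morpholin-4-yl)carbonyl)methyl in place of hydrogen on an amide-type nitrogen in a ring. Going by the values given here, no measured step touches this nitrogen, so the series gives no direct guide; the aryl changes only show that small changes there leave this assay unmoved beyond the scatter. For compound 4 a step of a 1.3-fold higher number from compound 2 to compound 4 (0.12 log units; within the scatter) is expected. Compound 4 is estimated at 3200 nM, with a range from 1000 nM to 10000 nM.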

Compound 4, half-maximal inhibitory concentration: 3320 nM
Estimate against measurement, compound 4: 1.0-fold (0.02 log units) below; low and high end bracket the measured number.
By their numbers in this assay, from the lowest: compounds 2, 1, 4 and 3 (each within the scatter of the next).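

In this assay, going by these compounds alone, placing ((morpholin-4-yl)carbonyl)methyl on the amide-type nitrogen in the ring gives a 1.4-fold higher number from compound 2 to compound 4 (0.14 log units; within the scatter), the first reading at this position. This nitrogen therefore takes the group, with its six-membered non-aromatic ring, without a change beyond the scatter. Nothing at hand accounts for this step.

As far as these compounds go, whether a carboxylic acid or an amine on the chain, or a plain methyl, would read the same remains open. So does whether this nitrogen change reads alike on the aryl groups of compound 1 and compound 3.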